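The compounds below may be only part of what the source reports. "The series", "measured", "known", "first", "only" and "open" are said of these compounds alone.

Measured so far:
- compound 1 `COc1cccc(C(=O)Nc2cc(-c3ccccc3)nn2-c2ccccc2)c1` — 1290 nM
- compound 2 `O=C(Nc1cc(-c2ccccc2)nn1-c1ccccn1)c1ccccc1` — > 10000 nM; this is a limit of the assay, not a number
- compound 3 `N#Cc1ccc(C(=O)/N=c2\cc(-c3ccccc3)n(C(=O)c3ccc(C#N)cc3)n2-c2ccccc2)cc1` — 5230 nM

In an assay on HEK293 cells for displacement of a labelled ligand from metabotropic glutamate receptor 5 (Rattus norvegicus) (a higher number here means a weaker inhibitor, a lower number a stronger inhibitor), compound 1 gives the lowest of the two numbers. Compound 3 sits higher, and the gap between compound 1 and compound 3 is beyond the scatter. Compound 2 stands at the limit of > 10000 nM in this assay, at which 1 of the 3 values shown sits, and gives no number to compare.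

Compound 4 `O=C(Nc1cc(-c2ccccc2)nn1-c1ccccc1)C1CCCC1` has not yet been measured. It differs from compound 1 in one place: cyclopentyl in place of 3-methoxyphenyl on a carbonyl carbon. Among the measured compounds shown here, no step between two measured compounds has been recorded that would show what such a change does, so the expectation rests only on the values of compound 1 and compound 3 and on the change itself. The estimate is for a modest weakening: the step from compound 1 to compound 4 is expected to be a 1.9-fold higher number from compound 1 to compound 4 (0.29 log units; within the scatter), around the edge of the scatter rather than clearly beyond it. Compound 4 is therefore estimated at 2500 nM, with a range from 800 nM to 8000 nM.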

Compound 4, inhibition constant: 11600 nM
Beside the measured number, compound 4's estimate is 4.6-fold (0.67 log units) below it; the whole stated range lies below it.
By their numbers in this assay, from the lowest: compound 1; then compound 3; then compound 4.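

In this assay, among the compounds shown here, cyclopentyl in place of 3-methoxyphenyl on a carbonyl carbon gives a 9.0-fold higher number from compound 1 to compound 4 (0.95 log units; beyond the scatter), the first change that can be read at a single place. The group on this carbonyl carbon therefore matters to the number: with one six-membered aromatic ring of carbon only giving way to one five-membered non-aromatic ring of carbon only, and the oxygen of the methoxy group gone, the step lies beyond the scatter. No measured property at hand accounts for this step.

This single step alters ring size, aromatic character and the oxygen together, so it does not show which of these changes carries the shift. The compounds shown also leave open whether cyclohexyl or 3-hydroxyphenyl on this carbonyl carbon would stay close to compound 1.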